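The source may report more compounds than this note shows. Statements on the series, on what has been measured and on what is new or still open speak of the compounds shown alone.

Compound 1 `CCN(CC)C(=O)c1nc2ccccc2n1Cc1ccccc1`: > 10000 nM
Compound 2 `CC(=O)N(Cc1ccccc1)c1cc(C)cc(C)c1`: 276 nM

Of the compounds shown here, two have been measured in an assay on membranes from HEK293 cells for displacement of a labelled ligand from Translocator protein (Homo sapiens), read by scintillation counting, with a stated time of 90 min; a higher number here means a weaker inhibitor, a lower number a stronger inhibitor. For compound 1 the reported value of > 10000 nM is a limit of the assay and not a number, as noted in the limit of > 10000 nM in this assay, at which 1 of the 2 values shown sits. For the measured compounds named here, compound 2 is the only compound with an actual number; in this assay compound 2 gives 276 nM.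

The next compound, compound 3 `COc1ccc(CN(C(C)=O)c2cc(C)cc(C)c2)cc1`, keeps the core of compound 2 and carries a single change: methoxy in place of hydrogen on an aromatic carbon, placed on an aromatic carbon of a six-membered aromatic ring of carbon only, para to a large group. Going by the values given here, no measured pair in this set shares this kind of change, so there is no measured step to lean on. The step from compound 2 to compound 3 is expected to be small, with a slight shift toward stronger binding at most, as a 1.4-fold lower number from compound 2 to compound 3 (0.14 log units; within the scatter). Compound 3 is therefore estimated at 200 nM in this assay, within a range from 60 nM to 700 nM.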

Compound 3, inhibition constant: 500 nM
Beside the measured number, compound 3's estimate is 2.5-fold (0.40 log units) below it, and the stated range covers the measured number.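

In this assay, methoxy in place of hydrogen on an aromatic carbon, para to a large group, gives a 1.8-fold higher number from compound 2 to compound 3 (0.26 log units; within the scatter), so this position takes the added group without a step that stands out from the scatter. For the compounds shown here, this is the first step in the set between measured compounds that differ in one place, and it covers only one group at one position. Nothing in the data shown gives a reason for this step.

On these data alone, whether a hydroxyl, an amine or a carboxylic acid in this same place would also stay within the scatter of compound 2 remains open. Also open, as far as these compounds go, is whether methoxy would give a similar step elsewhere on this ring, and whether a longer chain in place of the acetyl methyl would be tolerated.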